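Changing the Aryl Group on the Ring Nitrogen

The source may report more compounds than this note shows. Statements on the series, on what has been measured and on what is new or still open speak of the compounds shown alone.

Among the measured compounds shown here, compound 3 `C[C@H](Nc1ncnc2[nH]cnc12)c1nn(-c2ccc(C#N)cc2)c2cc(F)ccc12` gives 46% in a functional assay on Hep 3B2 cells (Homo sapiens) for inhibition, read by sulforhodamine B assay, with a stated time of 72 h, tested at 10 uM (on this read-out lower numbers stand for less inhibition and higher numbers for more inhibition at the one concentration tested (going by the name of the read-out)), the highest of the three numbers measured so far. Compound 1 `C[C@H](Nc1ncnc2[nH]cnc12)c1nn(-c2cccc(F)c2)c2cc(F)ccc12` gives 28% and compound 2 `C[C@H](Nc1ncnc2[nH]cnc12)c1nn(-c2cccnc2)c2cc(F)ccc12` gives 20% in this assay. The steps of a number 18 percentage points higher from compound 1 to compound 3 (beyond the scatter) and a number 26 percentage points higher from compound 2 to compound 3 (beyond the scatter) both lie beyond the scatter, while the step of a number 8 percentage points lower from compound 1 to compound 2 (within the scatter) does not. Compound 4 `C[C@H](Nc1ncnc2[nH]cnc12)c1nn(-c2ccccn2)c2cc(F)ccc12` differs from compound 3 in one place: pyridin-2-yl in place of 4-cyanophenyl on an aromatic nitrogen. The step of a number 26 percentage points higher from compound 2 to compound 3 (beyond the scatter) bears most on this change, as that step also exchanged pyridin-3-yl for 4-cyanophenyl; run the other way, a drop of similar size is expected. Compound 4 is therefore estimated to give 22% in this assay, with a range from 8% to 38%. The expected step is thus a number 24 percentage points lower from compound 3 to compound 4 (beyond the scatter).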

Compound 4, a percentage reported as inhibition, at one concentration (the size of the read-out at that concentration, not a potency): 12%
Compound 4: the middle estimate sits 10 percentage points above what was measured, within the range that was stated.
By their numbers in this assay, from the lowest: compounds 4, 2 and 1 (each within the scatter of the next, the first and the last beyond it); then compound 3.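

Pyridin-2-yl in place of 4-cyanophenyl gives the one large step at this aromatic nitrogen (a number 34 percentage points lower from compound 3 to compound 4 (beyond the scatter)), and pyridin-2-yl in place of 3-fluorophenyl also gives a drop (a number 16 percentage points lower from compound 1 to compound 4 (beyond the scatter)). The two pyridines cannot be told apart in this assay (a number 8 percentage points lower from compound 2 to compound 4 (within the scatter)), so compound 3 alone stands beyond the scatter of all the others. Nothing available explains these differences. As far as these compounds go, it remains open whether the nitrile itself matters, or whether a phenyl ring carrying an amine or a carboxylic acid in its place would give a similar number.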